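Dimethylamino for Methoxy on a Fused Nucleoside Core

The source may report more compounds than this note shows. Statements on the series, on what has been measured and on what is new or still open speak of the compounds shown alone.

In an ADME assay on BJ cells (Homo sapiens), read by MTT assay, with a stated time of 72 h (a higher number here means a weaker inhibitor, a lower number a stronger inhibitor), compound 2 `COc1ncnc2c1c(-c1cccs1)cn2[C@@H]1O[C@H](CO)[C@@H](O)[C@H]1O` gives 62800 nM. Among the compounds with values here, that is the only full number measured here; the second value recorded is a limit. Compound 1 `CN(C)c1ncnc2c1c(-c1ccsc1)cn2[C@@H]1O[C@H](CO)[C@@H](O)[C@H]1O` returns > 100000 nM, which is a limit of the assay and not a number. Within the data shown here, no measured pair of compounds differs in one place only, so no single-change step has been observed.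

Compound 3 `CN(C)c1ncnc2c1c(-c1cccs1)cn2[C@@H]1O[C@H](CO)[C@@H](O)[C@H]1O` differs from compound 2 by dimethylamino in place of methoxy on an aromatic carbon. Because compound 1, which also carries the dimethylamino group, sits at the limit of > 100000 nM in this assay, at which 1 of the 2 values shown sits, the change is expected to point toward weaker inhibition. The step of a 1.9-fold higher number from compound 2 to compound 3 (0.28 log units; within the scatter) is expected to be modest, possibly within the scatter of repeated measurements. On this basis compound 3 is estimated at 120000 nM, in the range 40000 nM to 400000 nM, with a real chance that the assay reports only a limit.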

Compound 3, half-maximal inhibitory concentration: > 100000 nM
Compound 3 ended at the assay's limit; the forecaster's own chance of this, stated with the estimate: 55%; the middle value lies beyond the limit too.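

Within the data shown here, the change of dimethylamino in place of methoxy on an aromatic carbon gives the first single-change step at this position: in this assay it shows an at least 1.5-fold higher number from compound 2 to compound 3 (0.20 log units; that floor lies within the scatter). As far as these compounds go, this is only a floor, so the true size of the step remains unknown, and the result does not establish a change larger than the usual scatter. With dimethylamino in this place, neither the thiophen-3-yl of compound 1 nor the thiophen-2-yl of compound 3 gives a full number, so the step between those two compounds cannot be read: the limit of > 100000 nM in this assay, at which 2 of the 3 values shown sit.

From the compounds shown here alone, how far past the limit compound 3 lies remains open. So does how a primary amine or an ethoxy chain in this place would read in this assay, and whether thiophen-3-yl would matter alongside methoxy.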